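The source may report more compounds than this note shows. Statements on the series, on what has been measured and on what is new or still open speak of the compounds shown alone.

Measured compounds:
Compound 1, `Cc1cc(OCc2c(-c3cc[nH]c(=O)c3Cl)noc2C(C)C)ccc1-c1ccc2c(C(=O)O)cn(C)c2c1`, gives 7000 nM in a functional assay for agonist activity at Bile acid receptor (Mus musculus), read by a luciferase reporter; on this read-out higher numbers stand for an effect only at larger amounts of compound and lower numbers for an effect already at smaller amounts.
Compound 2, `CC(C)c1onc(-c2ccc(S(C)(=O)=O)cc2Cl)c1COc1ccc(/C=C/c2cccc(C(=O)O)c2)c(Cl)c1`, gives only a limit in this assay, > 10000 nM.
Compound 3, `Cc1cc(OCc2c(-c3c(Cl)ccc(=O)n3C)noc2C(C)C)ccc1-c1ccc2c(C(=O)O)cn(C)c2c1`, gives 4000 nM in this assay.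

Where compound 3 stands: of the two numbers shown, the step of a 1.8-fold lower number from compound 1 to compound 3 (0.24 log units; within the scatter) shows that compound 3 and compound 1 cannot be told apart in this assay. The remaining value is a limit, (the limit of > 10000 nM in this assay, at which 1 of the 3 values shown sits), and belongs to compound 2 alone.

Compound 4, `COc1ccc(Cl)c(-c2noc(C(C)C)c2COc2ccc(-c3ccc4c(C(=O)O)cn(C)c4c3)c(C)c2)n1`, has the same atoms as compound 3 joined differently: a group of 9 heavy atoms (6 carbon, 1 nitrogen, 1 oxygen, 1 chlorine; one six-membered aromatic ring with 1 hetero atom) in place of a group of 9 heavy atoms (6 carbon, 1 nitrogen, 1 oxygen, 1 chlorine; one six-membered aromatic ring with 1 hetero atom), on an aromatic carbon. Going by the values given here, the one measured step that bears on this place is the step from compound 1 to compound 3, which exchanged the aryl group on the same carbon of the five-membered ring and gave a 1.8-fold lower number from compound 1 to compound 3 (0.24 log units; within the scatter), a change within the scatter. Compound 2 carries a different core and gives only a limit, so it offers no guide. With one exchange at this place already leaving the number essentially unchanged, the step of a 1.1-fold higher number from compound 3 to compound 4 (0.05 log units; within the scatter) is expected to stay within the scatter, with no direction favoured. Compound 4 is therefore estimated at 4500 nM in this assay, within a range of 1500 nM to 13000 nM.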

Compound 4, half-maximal effective concentration: 2000 nM
For compound 4 the middle estimate is 2.3-fold (0.35 log units) above the measured one; measured number inside the range.
By their numbers in this assay, from the lowest: compounds 4, 3 and 1 (each within the scatter of the next, the first and the last beyond it). At a limit, above all of these: compound 2.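

On the aromatic carbon next to the ring nitrogen, entry of the 3-chloro-6-methoxypyridin-2-yl group gives a 2.0-fold lower number from compound 3 to compound 4 (0.30 log units; within the scatter) in this assay, so the two arrangements of these same atoms cannot be told apart at this position. The position does, however, now yield its first step beyond the scatter, a 3.5-fold lower number from compound 1 to compound 4 (0.54 log units; beyond the scatter), which the earlier exchange between compound 1 and compound 3 did not provide, although this step is modest and compound 3 lies within the scatter of both neighbours. Nothing in the data shown accounts for this difference between the groups at this position.

Going by these compounds alone, what the methoxy group itself contributes stays open, since no compound here shows that group exchanged for a hydroxyl, an amine or an ethoxy group on the same shared core. Within the data shown here, it also remains unknown whether the chlorine of the 3-chloro-6-methoxypyridin-2-yl group matters, as no compound here carries a hydrogen, a fluorine or a methyl group in its place.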